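Cytotoxicity of Amine Variants on a Shared Core

The source may report more compounds than this note shows. Statements on the series, on what has been measured and on what is new or still open speak of the compounds shown alone.

Compound 1, `CCN(CC)Cc1cc(-c2ccccc2)n(Nc2ccnc3cc(Cl)ccc23)c1C`: 4380 nM
Compound 2, `Cc1c(CNC(C)(C)C)cc(-c2ccccc2)n1Nc1ccnc2cc(Cl)ccc12`: no result reported

In an ADME assay on WEHI13 cells (Mus musculus) for cytotoxicity, read by MTT assay (a lower number here means a stronger inhibitor, a higher number a weaker inhibitor), compound 1 gives 4380 nM. For compound 2 the entry in this assay reads "not determined" (no result reported), so compound 2 stands nowhere on the scale; only compound 1 gives a point of reference. Compound 3, `Cc1c(CNC[C@@H]2CCCN3CCCC[C@H]23)cc(-c2ccccc2)n1Nc1ccnc2cc(Cl)ccc12`, differs from compound 2 in one place: a group of 11 heavy atoms (10 carbon, 1 nitrogen; 2 six-membered non-aromatic rings with 1 hetero atom each) in place of a group of 4 heavy atoms (4 carbon; no ring), on an amine nitrogen. For the measured compounds named here, with no measured step between any two compounds, the size of the change in this assay cannot be read from data, and no shift beyond the scatter is expected in either direction. Compound 3 is estimated at 3500 nM, within 800 nM to 15000 nM.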

Compound 3, half-maximal inhibitory concentration: 7440 nM
For compound 3 the middle estimate is 2.1-fold (0.33 log units) below the measured one; measured number inside the range.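

The reading in this assay shows a 1.7-fold higher number from compound 1 to compound 3 (0.23 log units; within the scatter) when the ring-free amine group on the saturated chain carbon gives way to one with two six-membered non-aromatic rings. Cytotoxicity therefore tells these two compounds apart no better than repeat measurements would, even though the amine group grows considerably and gains two defined stereocentres. Nothing available explains this result. Still open, from the compounds shown here alone, is how a primary amine, a morpholine or a carboxylic acid at this place would read, and whether the mirror-image form of the two-ring group in compound 3 would give a similar number.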